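A carbonyloxy link replaces the carbamoyl link

The source may report more compounds than this note shows. Statements on the series, on what has been measured and on what is new or still open speak of the compounds shown alone.

In a functional assay on A549 cells (Homo sapiens) for inhibition, read by sulforhodamine B assay, with a stated time of 48 h (a lower number here means a stronger inhibitor of growth, a higher number a weaker inhibitor of growth), compound 2 (`CCCCCCCCCCCC[C@@H](O)[C@H]1CC[C@H]([C@H](O)CCCCCCCCCCC(=O)Nc2ccnn2C)O1`) gives 100000 nM as the higher of two numbers, and compound 1 (`CCCCCCCCCCCC[C@@H](O)[C@H]1CC[C@H]([C@H](O)CCCCCCCCCCNC(=O)c2ccnn2C)O1`) gives 12900 nM as the lower. Compound 3 (`CCCCCCCCCCCC[C@@H](O)[C@H]1CC[C@H]([C@H](O)CCCCCCCCCCOC(=O)c2ccnn2C)O1`) differs from compound 2 by ((1-methyl-1H-pyrazol-5-yl)carbonyl)oxy in place of (1-methyl-1H-pyrazol-5-yl)carbamoyl on a saturated chain carbon, ten or more bonds along the chain from an oxygen on a saturated carbon and a saturated ring carbon on a saturated chain carbon. Within the data shown here, the one measured step bearing on this is a 7.8-fold higher number from compound 1 to compound 2 (0.89 log units; beyond the scatter) and compound 1 there holds ((1-methyl-1H-pyrazol-5-yl)carbonyl)amino, whose carbonyl-bearing part returns in compound 3. A step of similar size is therefore expected, estimated as a 4.5-fold lower number from compound 2 to compound 3 (0.66 log units; beyond the scatter) toward a lower number. In this assay the estimate for compound 3 is 22000 nM (expected range 8000 nM to 70000 nM) for the coming measurement.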

Compound 3, concentration for 50% growth inhibition: 56200 nM
Compound 3: middle estimate off by 2.6-fold (0.41 log units), on the low side; the range from low to high includes it.
By their numbers in this assay, from the lowest: compound 1; then compounds 3 and 2 (each within the scatter of the next).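

In this assay, ((1-methyl-1H-pyrazol-5-yl)carbonyl)oxy in place of (1-methyl-1H-pyrazol-5-yl)carbamoyl gives a 1.8-fold lower number from compound 2 to compound 3 (0.25 log units; within the scatter), so these two links are not told apart at this position. Keeping the carbonyl on the ring is not enough to match the amino link, as ((1-methyl-1H-pyrazol-5-yl)carbonyl)oxy in place of ((1-methyl-1H-pyrazol-5-yl)carbonyl)amino gives a 4.4-fold higher number from compound 1 to compound 3 (0.64 log units; beyond the scatter). Nothing available explains why the amino link stands apart. Still open, on these data alone, is how an amine link, or a longer chain carrying the ((1-methyl-1H-pyrazol-5-yl)carbonyl)amino group, would compare with compound 1.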